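Swapping a Pyridine for a Furan on a Shared Core

The compounds below may be only part of what the source reports. "The series", "measured", "known", "first", "only" and "open" are said of these compounds alone.

Compound 3 `Oc1ccc(-c2cc(-c3ccncc3)nc(-c3cccc(Cl)c3)c2)cc1` carries a pyridin-4-yl group on its core, but in a functional assay on HCT-15 cells (Homo sapiens) for cytotoxicity, read by CCK-8 assay and cell counting, with a stated time of 2 days (a higher number here means a weaker inhibitor, a lower number a stronger inhibitor), compound 3 gives "not determined" (no result reported), so it stands without a number. The step to compound 4 `Oc1ccc(-c2cc(-c3cccc(Cl)c3)nc(-c3ccco3)c2)cc1` is furan-2-yl in place of pyridin-4-yl on an aromatic carbon. Two related compounds give a footing: in this assay compound 1 `Oc1ccc(-c2cc(-c3ccco3)nc(-c3ccccc3Cl)c2)cc1` gives 5460 nM, and compound 2 `Oc1cccc(-c2cc(-c3cccc(Cl)c3)nc(-c3ccco3)c2)c1` gives 2460 nM. Both carry the furan-2-yl group that compound 4 gains, and compound 4 shares the 4-hydroxyphenyl group of compound 1 and the 3-chlorophenyl group of compound 2. With no number for compound 3, no size or direction can be given for this step in this assay. Near the values of those two furan compounds, compound 4 is expected at 3500 nM, within a range from 1200 nM to 10000 nM.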

Compound 4, half-maximal inhibitory concentration: 8020 nM
Beside the measured number, compound 4's estimate is 2.3-fold (0.36 log units) below it, and the stated range covers the measured number.
By their numbers in this assay, from the lowest: compound 2; then compounds 1 and 4 (each within the scatter of the next).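

In this assay the furan-2-yl compounds show a 3.3-fold higher number from compound 2 to compound 4 (0.51 log units; beyond the scatter) with 4-hydroxyphenyl in place of 3-hydroxyphenyl, so where that hydroxy group sits makes a readable difference here. By contrast, 3-chlorophenyl in place of 2-chlorophenyl gives a 1.5-fold higher number from compound 1 to compound 4 (0.17 log units; within the scatter) and so shows no real change. The step from compound 3 cannot be read, and nothing available explains the other two steps. From the compounds shown here alone, whether an amine or a carboxylic acid in place of the furan-2-yl group would give a lower number stays open.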